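This account rests on a few compounds, and the source may have more. Where it says the series, first, only, none or still open, it means among the compounds named here.

Measured compounds:
compound 1 `COc1cc2ccc(=O)oc2cc1OCCCCOc1no[n+]([O-])c1S(=O)(=O)c1ccccc1` gives 3040 nM
compound 2 `COc1cc2ccc(=O)oc2cc1OCCCCCCOc1c[n+]([O-])on1` gives 4480 nM
compound 3 `COc1cc2cc(NC(C)=O)c(=O)oc2cc1OCCOc1no[n+]([O-])c1S(=O)(=O)c1ccccc1` gives 6890 nM

All three numbers come from a functional assay on MCF7 cells (Homo sapiens) for inhibition, read by MTT assay, with a stated time of 48 h; on this read-out lower numbers stand for stronger inhibition and higher numbers for weaker inhibition. Compound 1 gives the lowest of the three numbers. Compound 2 stands nearest to it, with a number that lies within the scatter of compound 1, so the two cannot be told apart on this read-out. Compound 3 stands furthest, and its number lies beyond the scatter from compound 1. Compound 3 also differs from compound 1 in more than one place, so its number alone says nothing about any single change.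

Compound 4 `COc1cc2cc(N)c(=O)oc2cc1OCCCCOc1no[n+]([O-])c1S(=O)(=O)c1ccccc1` has not yet been measured in this assay. It differs from compound 1 in one place: amino in place of hydrogen on an aromatic carbon. For the measured compounds named here, no step between measured compounds isolates an amino group at this position. Going by the values given here, the only neighbouring hint is compound 3, which carries an acetylamino group on the core together with a shorter chain and gives 6890 nM, whereas compound 1 gives 3040 nM; both changes sit in compound 3 at once. Among the compounds with values here, with no matching step to lean on, the step of a 1.2-fold higher number from compound 1 to compound 4 (0.06 log units; within the scatter) is expected to be small, in either direction, and most likely not beyond the scatter. Compound 4 is therefore estimated at 3500 nM, with a range from 1500 nM to 8000 nM.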

Compound 4, half-maximal inhibitory concentration: 2280 nM
For compound 4 the middle estimate is 1.5-fold (0.19 log units) above the measured one, within the range that was stated.
By their numbers in this assay, from the lowest: compounds 4, 1, 2 and 3 (each within the scatter of the next, the first and the last beyond it).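

In this assay, for the compounds shown here, amino in place of hydrogen on an aromatic carbon of the shared core gives the first step that isolates this position, a 1.3-fold lower number from compound 1 to compound 4 (0.12 log units; within the scatter), and this step lies within the scatter, so compound 1 and compound 4 cannot be told apart on this read-out. The earlier compounds shown here could not show this, since compound 3 carries its acetylamino group on the core together with a shorter chain; the new step shows that, with everything else as in compound 1, this position takes an amino group without any difference this read-out can detect. No measurement among those shown bears on what lies behind this result.

Going by these compounds, whether a methylamino group, a hydroxyl group or an acetylamino group at this position would also leave the number within the scatter, with the chain of compound 1 kept in place, stays open. On these data alone, it also stays open whether the amino group would give a similarly small step on a compound with a longer chain or without the sulfonyl group.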